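From 4-chlorobenzyl to benzyl: one more chloro removed

The compounds below may be only part of what the source reports. "The series", "measured", "known", "first", "only" and "open" are said of these compounds alone.

Measured in a functional assay on SK-BR-3 cells (Homo sapiens) for cytotoxicity, read by MTT assay, with a stated time of 72 h; on this read-out higher numbers stand for weaker inhibition and lower numbers for stronger inhibition:
- compound 1 `N[C@H]1CC[C@H](Nc2c(C(=O)NCc3ccc(Cl)cc3Cl)nc(Br)c3cccnc23)CC1`: 6000 nM
- compound 2 `CN(C)c1ccc(CNC(=O)c2nc(Br)c3cccnc3c2N[C@H]2CC[C@H](N)CC2)cc1`: "not determined" (no result reported)
- compound 3 `N[C@H]1CC[C@H](Nc2c(C(=O)NCc3ccc(Cl)cc3)nc(Br)c3cccnc23)CC1`: 2000 nM

Only two of these compounds have a number. Compound 3 holds the lower one at 2000 nM, and the nearest neighbour is compound 1 at 6000 nM. Compound 2 gives no number to compare.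

The next compound is compound 4 `N[C@H]1CC[C@H](Nc2c(C(=O)NCc3ccccc3)nc(Br)c3cccnc23)CC1`. It differs from compound 3 by a single change, (hydrogen in place of chloro on an aromatic carbon), which turns 4-chlorobenzyl into benzyl.

Among the measured compounds shown here, one measured step bears on this, and it is the same kind of change, hydrogen in place of chloro on an aromatic carbon: a 3.0-fold lower number from compound 1 to compound 3 (0.48 log units; beyond the scatter). That step was modest, and the chloro it removed is not the one that leaves now, so it offers only a weak guide. A slight lean towards a lower number is expected, but no firm shift beyond the scatter. The expected step is a 1.3-fold lower number from compound 3 to compound 4 (0.12 log units; within the scatter). For compound 4 the estimated value is 1500 nM, with an expected range from 500 nM to 5000 nM.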

Compound 4, half-maximal inhibitory concentration: 8000 nM
The estimate for compound 4 lay 5.3-fold (0.73 log units) below the measured number; the measured number lies above the stated range.
By their numbers in this assay, from the lowest: compound 3; then compounds 1 and 4 (each within the scatter of the next).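

In this assay, removing the chloro from the 4-chlorobenzyl group gives a 4.0-fold higher number from compound 3 to compound 4 (0.60 log units; beyond the scatter), so at this place, para to a large group, the chloro goes with the lower number. This runs opposite to the same exchange at the other chloro of the 2,4-dichlorophenyl group (a 3.0-fold lower number from compound 1 to compound 3 (0.48 log units; beyond the scatter)), so the direction of this exchange depends on where the chloro sits, and removing both chloros leaves the number within the scatter (a 1.3-fold higher number from compound 1 to compound 4 (0.12 log units; within the scatter)). Nothing available explains this reversal.

The compounds shown leave open whether the lower number needs chloro itself or whether another group at this place, such as fluoro, methyl or methoxy, would serve as well. Compound 2, with a dimethylamino group on its ring, gives no number, so an amine at this place remains an open question.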